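A few compounds are considered here, and "the series" means these few. Any claim that something is new, unique, unknown or untested is made for them only; others in the source may bear on it.

Working notes on the series. Compound 1 `Cn1cc(-c2cnc3c(-c4csc(C(=O)N[C@@H]5CCC[C@@H]5O)c4)cnn3c2)cn1` gives 43 nM in an assay for inhibition of MAP/microtubule affinity-regulating kinase 3 (Homo sapiens), read by HTRF, with a stated time of 2 h; on this read-out higher numbers stand for weaker inhibition and lower numbers for stronger inhibition. Compound 2 `Cn1cc(-c2cnc3c(-c4csc(C(=O)N[C@@H]5CCCC[C@H]5O)c4)cnn3c2)cn1` gives 24 nM in this assay. For the measured compounds named here, the one step so far, a 1.8-fold lower number from compound 1 to compound 2 (0.25 log units; within the scatter), is within the scatter, so compound 2 cannot be separated from compound 1 on these two numbers; it merely supplies the smaller of the two values without a real distinction.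

Compound 3 `Cn1cc(-c2cnc3c(-c4csc(C(=O)N[C@@H]5CCCC[C@H]5N)c4)cnn3c2)cn1` is the next member. The change from compound 2 is amino in place of hydroxy on a saturated ring carbon. Going by the values given here, no measured step in this set bears on the exchange of hydroxy for amino: the only step available concerns ring size. In the absence of any relevant step, the expectation for compound 3 in this assay is a number close to that of compound 2, with a step of a 1.7-fold higher number from compound 2 to compound 3 (0.22 log units; within the scatter) that is expected to be no larger than the scatter. The estimate for compound 3 is 40 nM, with a range from 10 nM to 160 nM.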

Compound 3, half-maximal inhibitory concentration: 1 nM
Beside the measured number, compound 3's estimate is 40-fold (1.60 log units) above it, and the stated range ends above it.
By their numbers in this assay, from the lowest: compound 3; then compounds 2 and 1 (each within the scatter of the next).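

In this assay, amino in place of hydroxy on a saturated ring carbon gives a 24-fold lower number from compound 2 to compound 3 (1.38 log units; beyond the scatter), whereas the change of ring size alone gave only a 1.8-fold lower number from compound 1 to compound 2 (0.25 log units; within the scatter); the group on this carbon therefore shows a large effect on the number that the ring-size step did not reveal. The wider exchange of 2-hydroxycyclopentyl for 2-aminocyclohexyl on the amide-type nitrogen gives a 43-fold lower number from compound 1 to compound 3 (1.63 log units; beyond the scatter). Nothing available explains why the amino group has this effect.

The compounds shown leave open whether the large step requires an unsubstituted amino group or would persist with methylamino or dimethylamino on the same carbon. They also leave open whether 2-aminocyclopentyl would match 2-aminocyclohexyl, which would show if ring size matters once the amino group is present.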